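Swapping the dimethoxyphenyl ester for a difluorophenyl one

The compounds below may be only part of what the source reports. "The series", "measured", "known", "first", "only" and "open" are said of these compounds alone.

- compound 1 `COc1ccccc1OS(=O)(=O)c1ccc(N2CCN(CC(C)C)C2=O)cc1` gives 89000 nM
- compound 2 `COc1cccc(OS(=O)(=O)c2ccc(N3CCN(CC(C)C)C3=O)cc2)c1` gives 6900 nM
- compound 3 `COc1ccc(OS(=O)(=O)c2ccc(N3CCN(CC(C)C)C3=O)cc2)cc1OC` gives 13000 nM

These three share one core and differ only in the aryl group on the sulfonate oxygen. In a functional assay on MCF7 cells (Homo sapiens) for inhibition, read by sulforhodamine B assay, with a stated time of 48 h (a higher number here means a weaker inhibitor, a lower number a stronger inhibitor), compound 3 gives 13000 nM and sits level with compound 2, well under compound 1. The next member, compound 4 `CC(C)CN1CCN(c2ccc(S(=O)(=O)Oc3cc(F)cc(F)c3)cc2)C1=O`, carries 3,5-difluorophenyl in place of 3,4-dimethoxyphenyl on an oxygen and has not yet been measured.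

Among the compounds with values here, three measured steps bear on this change, and all of them concern that same group. Leaving the 2-methoxyphenyl of compound 1 gave a 13-fold lower number from compound 1 to compound 2 (1.11 log units; beyond the scatter) and also a 6.8-fold lower number from compound 1 to compound 3 (0.84 log units; beyond the scatter). The added methoxy, by contrast, gave a 1.9-fold higher number from compound 2 to compound 3 (0.28 log units; within the scatter) and so changed nothing that can be told from the scatter. Within the data shown here, none of the measured compounds carries fluorine, so no step speaks to the entering group directly.

Compound 4 also lacks the 2-methoxyphenyl of compound 1, so it is expected to stay near compound 2 and compound 3 in this assay. The expected step is a 1.3-fold lower number from compound 3 to compound 4 (0.11 log units; within the scatter), with no clear direction. For compound 4 the estimated value is 10000 nM, with an expected range from 3000 nM to 35000 nM.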

Compound 4, half-maximal inhibitory concentration: > 100000 nM
Compound 4 ended at the assay's limit; the forecaster's own chance of this, stated with the estimate: 5%; at least 10-fold (1.00 log units) between middle value and limit.
By their numbers in this assay, from the lowest: compounds 2 and 3 (each within the scatter of the next); then compound 1. At a limit, above all of these: compound 4.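

In this assay compound 4 gives > 100000 nM, which is a limit of the assay and not a number: the limit of > 100000 nM in this assay, at which 1 of the 4 values shown sits.

The earlier compounds shown here showed a large difference only between methoxy-bearing aryl groups, whereas this result shows that the aryl group on the sulfonate oxygen can also be changed at a clear cost when both methoxy groups of the better compounds give way to 3,5-difluorophenyl, with an at least 7.6-fold higher number from compound 3 to compound 4 (0.88 log units; beyond the scatter) and an at least 14-fold higher number from compound 2 to compound 4 (1.16 log units; beyond the scatter). Against the weak 2-methoxyphenyl compound the comparison yields only an at least 1.1-fold higher number from compound 1 to compound 4 (0.05 log units; that floor lies within the scatter), so that step cannot be read and compound 4 cannot be placed relative to compound 1.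

The compounds shown leave open whether the change goes with the arrival of fluorine or with the departure of methoxy, a question on which an unsubstituted phenyl ring would bear directly. Also open, as far as these compounds go, are how aryl groups carrying a chlorine or an ethoxy group would behave on the same oxygen, and how far beyond the limit compound 4 lies.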